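The source may report more compounds than this note shows. Statements on the series, on what has been measured and on what is new or still open speak of the compounds shown alone.

Working notes on the series.

The shared core carries a prenyl chain and a methoxyphenyl group; the three measured compounds differ in what sits on the ring oxygens. Compound 1 `COc1ccc(-c2oc3c(CC=C(C)C)c(OCCOC(=O)CCCC(=O)O)cc(O)c3c(=O)c2OCCOC(=O)CCCC(=O)O)cc1` carries two glutarate half-ester chains and in a functional assay on A549 cells (Homo sapiens) for cytotoxicity, read by MTT assay (on this read-out higher numbers stand for weaker inhibition and lower numbers for stronger inhibition), compound 1 gives 6100 nM. Compound 2 `CCOC(=O)C(C)Oc1c(-c2ccc(OC)cc2)oc2c(CC=C(C)C)c(O)cc(O)c2c1=O` carries its ester on the oxygen of the pyranone ring and in this assay compound 2 gives 4600 nM. Compound 3 `CCOC(=O)C(C)Oc1cc(O)c2c(=O)c(O)c(-c3ccc(OC)cc3)oc2c1CC=C(C)C` carries the same ester on a phenol oxygen, and in this assay compound 3 gives 26500 nM.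

Compound 3 stands highest of the three numbers, and both gaps to it lie beyond the scatter: compound 1 sits nearest, compound 2 furthest. Going by the values given here, no single-point step between measured compounds is available, so nothing ties the ester position alone to the numbers.

Compound 4 `COc1ccc(-c2oc3c(CC=C(C)C)c(OCCCC(=O)O)cc(O)c3c(=O)c2O)cc1` differs from compound 3 in one place: 3-carboxypropyl in place of 1-(ethoxycarbonyl)ethyl on an oxygen on an aromatic ring. Among the compounds with values here, the nearest precedent is compound 1, whose acid-bearing chains give 6100 nM, a lower number than compound 3. On this basis the step from compound 3 to compound 4 is expected to run toward a lower number, of modest size, a 2.7-fold lower number from compound 3 to compound 4 (0.42 log units; beyond the scatter), possibly no further than the scatter. For compound 4 the expected value in this assay is 10000 nM, with a range from 3500 nM to 30000 nM.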

Compound 4, half-maximal inhibitory concentration: 19100 nM
For compound 4 the middle estimate is 1.9-fold (0.28 log units) below the measured one, within the range that was stated.
By their numbers in this assay, from the lowest: compounds 2 and 1 (each within the scatter of the next); then compounds 4 and 3 (each within the scatter of the next).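

Exchanging 1-(ethoxycarbonyl)ethyl for 3-carboxypropyl on an oxygen on an aromatic ring gives, in this assay, a 1.4-fold lower number from compound 3 to compound 4 (0.14 log units; within the scatter). Going by these compounds alone, this is the first comparison that isolates a single place, and it shows that, on this core and at this oxygen, an ethyl ester chain and a free carboxylic acid chain cannot be told apart on this read-out, even though the entering group brings 1 hydrogen-bond donor where the leaving group has 0. Nothing on hand speaks to why the two chains read alike.

Within the data shown here, the result covers only this one pair, so it remains open whether a primary amine, a simple methyl ether or a longer carboxylic acid chain on the same oxygen would produce a step beyond the scatter. Going by these compounds, it also remains open whether the same exchange would stay within the scatter if made on the ester chain of compound 2, which carries that chain on a different oxygen and has no one-place partner here.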